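Trimming a methoxy on the aryl ketone of compound 3

The compounds below may be only part of what the source reports. "The series", "measured", "known", "first", "only" and "open" are said of these compounds alone.

Three analogues sharing one core have been measured in a functional assay on HOP-62 cells (Homo sapiens) for cytotoxicity, read by sulforhodamine B assay, with a stated time of 48 h, tested at 100 uM; a lower number here means a stronger effect, a higher number a weaker effect of the compound at the concentration tested. Compound 1 `COc1cc(-c2cc(/C=C/C(=O)c3ccc(N)cc3)[nH]n2)cc(OC)c1OC` gives -98%, compound 2 `COc1cc(-c2cc(/C=C/C(=O)c3ccc(Cl)c(Cl)c3)[nH]n2)cc(OC)c1OC` gives -74%, and compound 3 `COc1ccc(C(=O)/C=C/c2cc(-c3cc(OC)c(OC)c(OC)c3)n[nH]2)cc1OC` gives -98%. Compound 3 thus sits at the strong end of the set: the step of no change at the digits printed from compound 1 to compound 3 (within the scatter) is within the scatter, while the step of a number 24 percentage points lower from compound 2 to compound 3 (beyond the scatter) is beyond it, so compound 2 stands apart as the weaker of the three.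

Compound 4 `COc1ccc(C(=O)/C=C/c2cc(-c3cc(OC)c(OC)c(OC)c3)n[nH]2)cc1` differs from compound 3 by hydrogen in place of methoxy on an aromatic carbon. Going by the values given here, no measured step removes a methoxy in this way; the nearest comparisons are the swaps of the whole aryl group on the carbonyl carbon, where no change at the digits printed from compound 1 to compound 3 (within the scatter) changed nothing and a number 24 percentage points lower from compound 2 to compound 3 (beyond the scatter) was only modest. Among the compounds with values here, since the one methoxy group on the aromatic ring is kept, compound 4 is expected to stay near compound 3, with a step of a number 8 percentage points higher from compound 3 to compound 4 (within the scatter) in this assay. Compound 4 is therefore estimated at -90%, in the range -100% to -60%.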

Compound 4, a percentage reported as activity, at one concentration (the size of the read-out at that concentration, not a potency): -79%
Estimate against measurement, compound 4: 11 percentage points below; the range from low to high includes it.
By their numbers in this assay, from the lowest: compounds 1 and 3 (each within the scatter of the next); then compounds 4 and 2 (each within the scatter of the next).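

Taking the methoxy off the 3,4-dimethoxyphenyl ketone is not silent in this assay: hydrogen in its place gives a number 19 percentage points higher from compound 3 to compound 4 (beyond the scatter), so this single group matters, although earlier swaps of the whole aryl group could not show that. The 4-methoxyphenyl ketone also separates from the 4-aminophenyl ketone, with a number 19 percentage points higher from compound 1 to compound 4 (beyond the scatter), but cannot be told apart from the 3,4-dichlorophenyl ketone, with a number 5 percentage points lower from compound 2 to compound 4 (within the scatter). Nothing available here accounts for these steps.

On these data alone, what remains open is whether the effect depends on methoxy itself or on any group at that aromatic carbon. Hydroxyl, fluorine or ethoxy there would address this, and it is also open what happens if the remaining methoxy is replaced by hydrogen.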